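Cytotoxicity notes: compound 3 to compound 4

The source may hold more compounds than are shown below. What is called first, only, known or untested is meant among the compounds shown, and "the series" means these compounds.

In an ADME assay on HEK-293T cells (Homo sapiens) for cytotoxicity, read by CCK-8 assay, with a stated time of 24 h (on this read-out lower numbers stand for higher toxicity in this test and higher numbers for lower toxicity in this test), compound 3 (`Cn1cc(SCC(=O)N(Cc2ccccc2)Cc2ccccc2)c2ccccc21`) gives 91200 nM as the only number shown. Compound 4 (`O=C(CSc1c[nH]c2ccccc12)N(Cc1ccccc1)Cc1ccccc1`) differs from it by hydrogen in place of methyl on an aromatic nitrogen with hydrogen in place of methyl on an aromatic nitrogen. Compound 1 (`O=C(CSc1c[nH]c2c(Br)cccc12)N(Cc1ccccc1)Cc1ccccc1`) has hydrogen on that nitrogen and gives > 100000 nM as a limit of the assay. Compound 2 (`O=C(CSc1c[nH]c2ccccc12)NCc1ccccc1`) has hydrogen there too and gives > 100000 nM as a limit of the assay. On that reading the expected 1.1-fold higher number from compound 3 to compound 4 (0.04 log units; within the scatter) is small, toward higher numbers if at all, and no larger than the usual scatter. For compound 4 the estimate is 100000 nM with an expected range from 50000 nM to 200000 nM and a report as a limit is likely.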

Compound 4, half-maximal cytotoxic concentration: > 100000 nM
Compound 4: a limit, no number; the forecaster's own chance of this, stated with the estimate: 65%; the middle value lies on the limit itself.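

In this assay, hydrogen in place of methyl on an aromatic nitrogen gives an at least 1.0-fold higher number from compound 3 to compound 4 (0.04 log units; that floor lies within the scatter), so no effect of this change at this position can be read. With limits at both ends, the steps to compound 4 from compound 2 and from compound 1 cannot be read. What the series can show here is capped by the top of the assay: the limit of > 100000 nM in this assay, at which 3 of the 4 values shown sit.

From the compounds shown here alone, whether a longer chain or an amine on that aromatic nitrogen would give a number under that limit stays open. So does the size of any difference among compound 1, compound 2 and compound 4.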